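This account rests on a few compounds, and the source may have more. Where it says the series, first, only, none or still open, it means among the compounds named here.

A small set of compounds shares one core and differs in the group on an amine nitrogen in a ring. In an in vitro ADME assay on microsomes from liver (Homo sapiens) for metabolic stability, tested at 1 uM (a lower number here means that the compound disappears faster, a higher number that the compound lasts longer), compound 1 `O=C(c1cccnc1)N1CCC(NS(=O)(=O)c2cc(S(=O)(=O)c3ccccc3)ccc2C(F)(F)F)CC1` gives 0.1 h. Compound 2 `O=C(c1ccc(Cl)nc1)N1CCC(NS(=O)(=O)c2cc(S(=O)(=O)c3ccccc3)ccc2C(F)(F)F)CC1` gives > 0.5 h, which is a limit of the assay and not a number. Compound 3 `CN(C)c1ccc(C(=O)N2CCC(NS(=O)(=O)c3cc(S(=O)(=O)c4ccccc4)ccc3C(F)(F)F)CC2)cn1` gives 0.05 h, which places it at the low end of the values shown, level with compound 1 within the scatter.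

The change to compound 4 `O=C(O)c1cccc(S(=O)(=O)N2CCC(NS(=O)(=O)c3cc(S(=O)(=O)c4ccccc4)ccc3C(F)(F)F)CC2)c1` is larger than any measured so far: (3-carboxyphenyl)sulfonyl in place of (6-(dimethylamino)pyridin-3-yl)carbonyl on an amine nitrogen in a ring. In words, (3-carboxyphenyl)sulfonyl comes in place of (6-(dimethylamino)pyridin-3-yl)carbonyl on an amine nitrogen in a ring. Going by the values given here, no measured step makes this swap, so the guidance is indirect. Among the compounds with values here, three steps changed only one group on the departing aromatic ring: an at least 5.0-fold higher number from compound 1 to compound 2 (0.69 log units; beyond the scatter), a 2.0-fold lower number from compound 1 to compound 3 (0.30 log units; within the scatter) and an at least 10-fold lower number from compound 2 to compound 3 (1.00 log units; beyond the scatter). They show that this end of the molecule can shift the half-life widely, though not always, since the second step stays within the scatter. Within the data shown here, with compound 3 at 0.05 h, the one upward example, an at least 5.0-fold higher number from compound 1 to compound 2 (0.69 log units; beyond the scatter), suggests a rise of similar size. The expected change is a 5.0-fold higher number from compound 3 to compound 4 (0.70 log units; beyond the scatter). For compound 4 the estimated half-life is 0.25 h, with an expected range from 0.07 h to 0.6 h.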

Compound 4, half-life: > 0.5 h
Compound 4: a limit, no number; the forecaster's own chance of this, stated with the estimate: 30%; at least 2.0-fold (0.30 log units) between middle value and limit.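

The swap shows that this position on the amine nitrogen in a ring tolerates more than changes on the pyridine ring: replacing the whole (pyridin-3-yl)carbonyl type of group with (3-carboxyphenyl)sulfonyl keeps the compound in this assay far longer, with an at least 10-fold higher number from compound 3 to compound 4 (1.00 log units; beyond the scatter) and an at least 5.0-fold higher number from compound 1 to compound 4 (0.69 log units; beyond the scatter). Among the compounds shown, a chloro on the pyridine ring is therefore no longer the only change that lifts the half-life, and a carbonyl on this nitrogen is not needed for a long half-life. Compound 4 gives > 0.5 h, which is a limit of the assay and not a number, and its step to or from compound 2 cannot be read because both compounds rest on the same limit: the limit of > 0.5 h in this assay, at which 2 of the 4 values shown sit.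

The compounds shown leave open whether the sulfonyl link or the carboxylic acid carries the rise, as the two enter together in compound 4. Going by these compounds, a plain phenylsulfonyl group on this nitrogen, without the carboxylic acid, and a benzoyl group carrying the carboxylic acid would separate the two, and how far the half-life of compound 4 really reaches also stays unknown.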